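The source may report more compounds than this note shows. Statements on the series, on what has been measured and on what is new or still open speak of the compounds shown alone.

In a functional assay on MCF7 cells (Homo sapiens) for inhibition, read by MTT assay, with a stated time of 24 h (a higher number here means a weaker inhibitor of growth, a lower number a stronger inhibitor of growth), compound 1 `Cn1cc(-c2nc3ccccc3n2C(=O)c2ccccc2)c2ccccc21` stands at 43700 nM and compound 2 `COc1ccccc1C(=O)n1c(-c2cn(C)c3ccccc23)nc2ccccc21` at 32100 nM within the scatter of compound 1, so the two numbers sit level. Compound 3 `COc1cccc(C(=O)n2c(-c3cn(C)c4ccccc34)nc3ccccc32)c1` carries 3-methoxyphenyl in place of 2-methoxyphenyl on a carbonyl carbon with the rest of the structure unchanged. Going by the values given here, the one measured step bearing on this is a 1.4-fold lower number from compound 1 to compound 2 (0.13 log units; within the scatter) for methoxy in place of hydrogen on an aromatic carbon. Among the compounds with values here, on that evidence no step beyond the scatter is expected in this assay in either direction, although no measured pair compares 2-methoxyphenyl with 3-methoxyphenyl directly. The estimated step is a 1.1-fold higher number from compound 2 to compound 3 (0.04 log units; within the scatter) as a working expectation. Compound 3 is estimated at 35000 nM with an expected range from 16000 nM to 75000 nM for now.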

Compound 3, concentration for 50% growth inhibition: 15700 nM
For compound 3 the middle estimate is 2.2-fold (0.35 log units) above the measured one, and the stated range ends above it.
By their numbers in this assay, from the lowest: compound 3; then compounds 2 and 1 (each within the scatter of the next).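

With the same atoms joined differently, a 2.0-fold lower number from compound 2 to compound 3 (0.31 log units; beyond the scatter) in this assay shows that where the methoxy group sits on this aromatic ring can move the number beyond the scatter, though only modestly. The presence of methoxy alone did not show this: a 1.4-fold lower number from compound 1 to compound 2 (0.13 log units; within the scatter) stays within the scatter, whereas a 2.8-fold lower number from compound 1 to compound 3 (0.44 log units; beyond the scatter) lies beyond it, so in these three compounds the added methoxy clears the scatter only as 3-methoxyphenyl. No measurement shown accounts for the difference between the two methoxyphenyl groups.

On these data alone, whether this step is specific to methoxy remains open, since a longer ethoxy chain, an amine such as dimethylamino or a carboxylic acid on the same ring would test that. As far as these compounds go, whether the same step appears on any other core also remains open.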